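The source may hold more compounds than are shown below. What is called first, only, known or untested is meant among the compounds shown, and "the series" means these compounds.

Measured compounds:
Compound 1, `CCCCC(O)Cn1cc(CN(C)CCCc2ccccc2)nn1`: 37%
Compound 2, `CCCCNC(=O)OCC(O)Cn1cc(CN(C)CC2CCCCC2)nn1`: 12%
Compound 3, `CN(Cc1cn(CC(O)COC(=O)c2ccccc2)nn1)CC1CCCCC1`: 6%

These three compounds were tested in an assay on nucleic acid for inhibition of Nucleic Acid, read by fluorescence, tested at 100 uM; a lower number here means less inhibition, a higher number more inhibition at the concentration tested (going by the name of the read-out). Compound 3 stands at the low end of the three numbers, though only by a step within the scatter: a number 6 percentage points lower from compound 2 to compound 3 (within the scatter), whereas compound 1 gives a number well beyond the scatter above it. Compound 4, `CCCCC(O)Cn1cc(CN(C)CC2CCCCC2)nn1`, has not yet been measured. It differs from compound 3 in one place: propyl in place of benzoyloxy on a saturated chain carbon, two bonds along the chain from an oxygen on a saturated carbon. Among the compounds with values here, no measured step covers this change. Within the data shown here, the only measured step, a number 6 percentage points lower from compound 2 to compound 3 (within the scatter), swaps groups on the carbonyl carbon and does not remove the ester oxygen or the aromatic ring, so it gives little guidance. Compound 4 shares its propyl-bearing chain with compound 1, which differs elsewhere, so the value of compound 1, 37%, only hints that this chain can sit on a compound giving a larger number. The step of a number 14 percentage points higher from compound 3 to compound 4 (beyond the scatter) is therefore expected to be a modest rise, uncertain in size. Compound 4 is estimated at 20%, with a range from 4% to 40%.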

Compound 4, a percentage reported as inhibition, at one concentration (the size of the read-out at that concentration, not a potency): 47%
Beside the measured number, compound 4's estimate is 27 percentage points below it, and the stated range ends below it.
By their numbers in this assay, from the lowest: compounds 3 and 2 (each within the scatter of the next); then compounds 1 and 4 (each within the scatter of the next).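

In this assay propyl in place of benzoyloxy gives a number 41 percentage points higher from compound 3 to compound 4 (beyond the scatter) and propyl in place of (butylcarbamoyl)oxy gives a number 35 percentage points higher from compound 2 to compound 4 (beyond the scatter) in compounds that share the cyclohexyl group, so this place on the saturated chain matters far more than the earlier swap on the carbonyl carbon could show. Cyclohexyl in place of phenethyl on the carbon bound to the amine nitrogen gives a number 10 percentage points higher from compound 1 to compound 4 (within the scatter) and so leaves compound 1 and compound 4 level within the scatter. Nothing available explains why propyl and the two larger oxygen-linked groups differ so much.

From the compounds shown here alone, it remains open whether a longer chain such as hexyl would hold the number at this place. A hydroxyl group or an amine at the end of the chain is equally untested here.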